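The source may report more compounds than this note shows. Statements on the series, on what has been measured and on what is new or still open speak of the compounds shown alone.

Compound 3 `O=C(Nc1cc(-c2ccccc2)nn1-c1ccccc1)c1cnccn1` gives 400 nM in an assay on isolated protein with metabotropic glutamate receptor 5 (Rattus norvegicus) as the target (on this read-out higher numbers stand for an effect only at larger amounts of compound and lower numbers for an effect already at smaller amounts), the highest number among the three measured amides; compound 2 `O=C(Nc1cc(-c2ccccc2)nn1-c1ccccc1)c1ccc(F)cc1` gives 50 nM and compound 1 `O=C(Nc1cc(-c2ccccc2)nn1-c1ccccc1)c1ccc(F)c(F)c1` gives 20 nM. Compound 4 `O=C(Nc1cc(-c2ccccc2)nn1-c1ccccc1)c1ccc(C(F)(F)F)cc1` carries the change (4-(trifluoromethyl)phenyl in place of pyrazin-2-yl on a carbonyl carbon). Going by the values given here, the steps that bear on it are a 20-fold higher number from compound 1 to compound 3 (1.30 log units; beyond the scatter) and an 8.0-fold higher number from compound 2 to compound 3 (0.90 log units; beyond the scatter), both running from a substituted phenyl amide to the pyrazine amide. Among the compounds with values here, compound 4 runs the other way, though with a trifluoromethyl substituent that no measured compound carries, so the size of the return is uncertain. The expected step is therefore a 10-fold lower number from compound 3 to compound 4 (1.00 log units; beyond the scatter), toward a lower number. For compound 4 the estimate is 40 nM, within the range 15 nM to 120 nM.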

Compound 4, half-maximal effective concentration: 20 nM
Compound 4: the middle estimate sits 2.0-fold (0.30 log units) above what was measured, and the stated range covers the measured number.
By their numbers in this assay, from the lowest: compounds 1 and 4 (each within the scatter of the next); then compound 2; then compound 3.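

In this assay, 4-(trifluoromethyl)phenyl on the carbonyl carbon reverses the pyrazin-2-yl penalty in full, with a 20-fold lower number from compound 3 to compound 4 (1.30 log units; beyond the scatter). Trifluoromethyl in place of fluoro on an aromatic carbon gives a 2.5-fold lower number from compound 2 to compound 4 (0.40 log units; beyond the scatter), so this position accepts trifluoromethyl, while the swap for 3,4-difluorophenyl gives no change at the digits printed from compound 1 to compound 4 (within the scatter). Nothing here accounts for these steps.

On these data alone, whether an amine, a carboxylic acid or a methoxy group on that aromatic carbon would fit these numbers stays open. The compounds shown also do not separate the contribution of each ring nitrogen of pyrazin-2-yl, which a pyridin-2-yl group on the carbonyl carbon would address.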